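Swapping Methyl for Trifluoromethyl on the Benzyl Ring

The source may report more compounds than this note shows. Statements on the series, on what has been measured and on what is new or still open speak of the compounds shown alone.

Measured compounds:
- compound 1, `Nc1ccc(/C=C2\SC(=O)N(Cc3ccccc3)C2=O)cc1`, 38000 nM
- compound 2, `Cc1ccc(CN2C(=O)S/C(=C\c3ccc(N)cc3)C2=O)cc1`, 94000 nM

Both compounds were tested in a functional assay on L1210 cells (Mus musculus) for cytotoxicity, read by cell counting, with a stated time of 2 days; a higher number here means a weaker inhibitor, a lower number a stronger inhibitor. Going by the values given here, compound 2 gives the higher of the two numbers, and the only step between measured compounds runs toward it: a 2.5-fold higher number from compound 1 to compound 2 (0.39 log units; beyond the scatter). So the one change seen so far, putting methyl in place of hydrogen on an aromatic carbon, weakened inhibition by a modest amount.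

Compound 3, `Nc1ccc(/C=C2\SC(=O)N(Cc3ccc(C(F)(F)F)cc3)C2=O)cc1`, is not yet measured. Its change from compound 2 is trifluoromethyl in place of methyl on an aromatic carbon. Among the compounds with values here, no measured pair shows trifluoromethyl in place of methyl on an aromatic carbon, so only the step from compound 1 to compound 2 bears on it, and only loosely: it tells that this position tolerates a group without a large shift, but it does not tell which way a larger group will push the number. The expectation is therefore a step of modest size at most, with the direction open.

Compound 3 is estimated to give 120000 nM, within a range of 40000 nM to 350000 nM, which means an expected step of a 1.3-fold higher number from compound 2 to compound 3 (0.11 log units; within the scatter).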

Compound 3, half-maximal inhibitory concentration: 6000 nM
For compound 3 the middle estimate is 20-fold (1.30 log units) above the measured one, and the stated range ends above it.
By their numbers in this assay, from the lowest: compound 3; then compound 1; then compound 2.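

In this assay, going by these compounds alone, this position proves far more sensitive than the first pair of compounds suggested, with a large step of a 16-fold lower number from compound 2 to compound 3 (1.19 log units; beyond the scatter) when trifluoromethyl takes the place of methyl on the aromatic carbon para to a large group. The new group also outperforms plain hydrogen, with a 6.3-fold lower number from compound 1 to compound 3 (0.80 log units; beyond the scatter), whereas methyl moved the number the other way, with a 2.5-fold higher number from compound 1 to compound 2 (0.39 log units; beyond the scatter), so the two groups shift the result in opposite directions from the same starting point. Size alone therefore does not set the outcome here, since two groups on the same carbon, each replacing hydrogen, give opposite shifts, and no measurement shown here explains why this happens.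

The compounds shown leave open how a chlorine atom, a methoxy group or a nitrile on this carbon would compare with trifluoromethyl and methyl. They also leave open whether trifluoromethyl would give a similarly low number on another carbon of this ring, or with the amine on the other side of the shared core replaced by a hydroxyl group.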